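Heteroaryl replacement on the shared core: pyridine to pyrimidine

The compounds below may be only part of what the source reports. "The series", "measured", "known", "first", "only" and "open" are said of these compounds alone.

Compound 1 `CC(C)c1ccc(-c2nc(N)c3cc(Cc4ccccc4)sc3n2)o1` and compound 2 `Nc1nc(-c2ccccn2)nc2sc(Cc3ccccc3)cc12` share one core and differ only in the aryl group attached to it. In a functional assay on CHO-K1 cells for antagonist activity at adenosine receptor A1 (Homo sapiens), read by a beta-galactosidase reporter and cAMP accumulation, with stated times of 15 min and 6 h (on this read-out lower numbers stand for stronger inhibition and higher numbers for weaker inhibition), compound 1 gives 283 nM, while compound 2 gives 3710 nM. For the measured compounds named here, the single measured step, a 13-fold higher number from compound 1 to compound 2 (1.12 log units; beyond the scatter), shows that exchanging the five-membered furan-type substituent for a six-membered pyridin-2-yl ring weakens inhibition markedly. Compound 2 therefore stands at the weaker end of the two numbers available.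

Compound 3 `Nc1nc(-c2ncccn2)nc2sc(Cc3ccccc3)cc12` is the next member; its change relative to compound 2 is pyrimidin-2-yl in place of pyridin-2-yl on an aromatic carbon. Going by the values given here, no measured step addresses this exact swap; the only step at hand, a 13-fold higher number from compound 1 to compound 2 (1.12 log units; beyond the scatter), concerns a different replacement at the same carbon and indicates that the core tolerates a six-membered ring there only poorly. On that basis, a step of about a 1.3-fold higher number from compound 2 to compound 3 (0.13 log units; within the scatter) is expected, small and likely within the scatter, with a mild lean toward a higher number. Compound 3 is thus estimated at 5000 nM in this assay, with a range of 1500 nM to 16000 nM.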

Compound 3, inhibition constant: 618 nM
Compound 3: middle estimate off by 8.1-fold (0.91 log units), on the high side; measured number outside the range, below it.
By their numbers in this assay, from the lowest: compound 1; then compound 3; then compound 2.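

At this carbon, between two ring nitrogen atoms, ring size alone does not set the number in this assay: with a six-membered aromatic ring kept in place, pyrimidin-2-yl for pyridin-2-yl gives a 6.0-fold lower number from compound 2 to compound 3 (0.78 log units; beyond the scatter), so a single added ring nitrogen in the substituent moves the result beyond the scatter. The earlier reading of compound 2 as a sign that six-membered rings fare poorly here does not hold as a general rule, since compound 3 goes against it, although 5-isopropylfuran-2-yl still gives the lowest number of the three, with a 2.2-fold higher number from compound 1 to compound 3 (0.34 log units; beyond the scatter). No measurement on hand explains why the two six-membered rings differ.

The compounds shown leave open how a phenyl ring, with no ring nitrogen, or an unsubstituted furan-2-yl group would read at this carbon, and therefore how much of the position of compound 1 belongs to the furan ring and how much to its isopropyl group. From the compounds shown here alone, it also remains open whether the gain seen with pyrimidin-2-yl depends on where the ring nitrogen atoms sit, which a pyrimidin-4-yl or pyrazin-2-yl group at the same carbon would address.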